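A few compounds are considered here, and "the series" means these few. Any claim that something is new, unique, unknown or untested is made for them only; others in the source may bear on it.

Measured compounds:
compound 1 `N[C@H]1CC[C@H](Nc2c(C(=O)NCc3cccc(C(F)(F)F)c3)nc(Br)c3cccnc23)CC1` — 15000 nM
compound 2 `N[C@H]1CC[C@H](Nc2c(C(=O)NCc3ccc(F)cc3)nc(Br)c3cccnc23)CC1` — 2000 nM
compound 3 `COc1ccc(CNC(=O)c2nc(Br)c3cccnc3c2N[C@H]2CC[C@H](N)CC2)cc1` — "not determined" (no result reported)

The series shares one core, and the amide substituent is where it varies. In a functional assay on MCF7 cells (Homo sapiens) for cytotoxicity, read by MTT assay, with a stated time of 72 h (a lower number here means a stronger inhibitor, a higher number a weaker inhibitor), compound 1 gives 15000 nM and compound 2 gives 2000 nM; the step of a 7.5-fold lower number from compound 1 to compound 2 (0.88 log units; beyond the scatter) shows that changing the group on the amide nitrogen moves the number by a modest but real amount. Compound 3 has no number in this assay, so its standing cannot be placed against the other two; it is known only as a structure.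

Compound 4 `N[C@H]1CC[C@H](Nc2c(C(=O)NC3CCCCC3)nc(Br)c3cccnc23)CC1` differs from compound 3 by cyclohexyl in place of 4-methoxybenzyl on an amide-type nitrogen. For the measured compounds named here, no measured step covers this change; the step from compound 1 to compound 2 is the only guide, and it concerns a different part of the amide substituent. The expectation is therefore loose: a value somewhere in the range spanned by compounds 1 and 2, with no direction stated. For compound 4 the estimate is 5000 nM, within 800 nM to 30000 nM.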

Compound 4, half-maximal inhibitory concentration: 5200 nM
Compound 4: middle estimate off by 1.0-fold (0.02 log units), on the low side, within the range that was stated.
By their numbers in this assay, from the lowest: compound 2; then compound 4; then compound 1.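

Until now, only benzyl groups carrying a substituent on the aromatic ring had numbers at this amide-type nitrogen. In this assay, cyclohexyl gives a 2.6-fold higher number from compound 2 to compound 4 (0.41 log units; beyond the scatter) and a 2.9-fold lower number from compound 1 to compound 4 (0.46 log units; beyond the scatter), so among these three compounds an aromatic ring on this nitrogen is not needed for a number in this range, and the non-aromatic ring falls inside the span set by the two benzyl compounds. Compound 3 has no number, so the change from 4-methoxybenzyl to cyclohexyl itself cannot be read, and nothing available accounts for the order of the three values.

The compounds shown leave open how an open hexyl chain, or a cyclohexyl ring carrying an amine or a carboxylic acid, would read on this nitrogen. They also leave open whether any group here can bring the number lower than that of compound 2.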